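Swapping chloro for iodo on an aromatic ring

The source may hold more compounds than are shown below. What is called first, only, known or untested is meant among the compounds shown, and "the series" means these compounds.

Measured in a functional assay on M21 cells (Homo sapiens) for antiproliferative activity, read by sulforhodamine B assay, with a stated time of 48 h; on this read-out higher numbers stand for weaker inhibition and lower numbers for stronger inhibition:
- compound 1 `CCN1CCN(c2ccc(S(=O)(=O)Oc3ccccc3OC)cc2)C1=O`: > 100000 nM (a limit)
- compound 2 `CCN1CCN(c2ccc(S(=O)(=O)Oc3cccc(OC)c3)cc2)C1=O`: 7000 nM
- compound 3 `CCN1CCN(c2ccc(S(=O)(=O)Oc3cccc(Cl)c3)cc2)C1=O`: 3900 nM

For the measured compounds named here, compound 3, at 3900 nM, and compound 2, at 7000 nM, are the only two with a real number, and they lie within the scatter of each other. Compound 1 gives only a limit, > 100000 nM.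

Compound 4 `CCN1CCN(c2ccc(S(=O)(=O)Oc3cccc(I)c3)cc2)C1=O` differs from compound 3 by iodo in place of chloro on an aromatic carbon, meta to a large group: iodo in place of chloro on an aromatic carbon. The closest measured change is also a swap of one group on an aromatic carbon, and it gave a 1.8-fold lower number from compound 2 to compound 3 (0.25 log units; within the scatter). The steps of an at least 14-fold lower number from compound 1 to compound 2 (1.15 log units; beyond the scatter) and an at least 25-fold lower number from compound 1 to compound 3 (1.40 log units; beyond the scatter) are far larger, but both start from the 2-methoxyphenyl of compound 1, which compound 4 does not carry. They therefore bear on this swap only weakly. In this assay the expected result is a 1.3-fold lower number from compound 3 to compound 4 (0.11 log units; within the scatter), so no shift beyond the scatter is anticipated. For compound 4 the estimated value is 3000 nM, with an expected range of 1200 nM to 8000 nM.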

Compound 4, half-maximal inhibitory concentration: 2200 nM
Compound 4: middle estimate off by 1.4-fold (0.13 log units), on the high side; the range from low to high includes it.
By their numbers in this assay, from the lowest: compounds 4, 3 and 2 (each within the scatter of the next, the first and the last beyond it). At a limit, above all of these: compound 1.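

In this assay there is a 1.8-fold lower number from compound 3 to compound 4 (0.25 log units; within the scatter) and so chloro and iodo cannot be told apart at this place on the ring. Iodo does separate from methoxy on the same aromatic carbon, with a 3.2-fold lower number from compound 2 to compound 4 (0.50 log units; beyond the scatter) and this is the first gap beyond the scatter among the compounds carrying their group there, since chloro and methoxy stayed within it. Putting 3-iodophenyl in place of 2-methoxyphenyl on the oxygen gives an at least 45-fold lower number from compound 1 to compound 4 (1.65 log units; beyond the scatter) and that size is a bound, not a measured distance.

As far as these compounds go, whether an amine, a carboxylic acid or a longer chain on this aromatic carbon would keep a number like these stays open, as does whether bromo or fluoro would fall in with chloro and iodo. Compound 1 gives only a limit, so the true size of its steps also stays open: the limit of > 100000 nM in this assay, at which 1 of the 4 values shown sits.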